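A few compounds are considered here, and "the series" means these few. Any claim that something is new, unique, unknown or untested is made for them only; others in the source may bear on it.

In a functional assay on Ehrlich cells (Mus musculus) for cytotoxicity, with a stated time of 48 h (on this read-out lower numbers stand for stronger inhibition of growth and higher numbers for weaker inhibition of growth), compound 1 (`COc1ccc(/C=N/C(C#N)=C(/C#N)NC(=O)NS(=O)(=O)c2ccc(C)cc2)cc1`) gives 10000 nM and compound 2 (`COc1cc(/C=N/C(C#N)=C(/C#N)NC(=O)NS(=O)(=O)c2ccc(C)cc2)cc(OC)c1`) gives 25000 nM as the higher of the two numbers. Compound 3 (`COc1cccc(/C=N/C(C#N)=C(/C#N)NC(=O)NS(=O)(=O)c2ccc(C)cc2)c1OC`) carries 2,3-dimethoxyphenyl in place of 3,5-dimethoxyphenyl on a carbon with a double bond to nitrogen. Within the data shown here, the only measured step that bears on this is a 2.5-fold higher number from compound 1 to compound 2 (0.40 log units; beyond the scatter) for 3,5-dimethoxyphenyl in place of 4-methoxyphenyl, a modest one. In this assay a step of similar modest size is expected, and the estimate takes it toward a lower number as a 2.1-fold lower number from compound 2 to compound 3 (0.32 log units; beyond the scatter) with wide uncertainty. For compound 3 the estimated value is 12000 nM (expected range 5000 nM to 30000 nM).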

Compound 3, concentration for 50% growth inhibition: 27000 nM
Beside the measured number, compound 3's estimate is 2.3-fold (0.35 log units) below it; low and high end bracket the measured number.
By their numbers in this assay, from the lowest: compound 1; then compounds 2 and 3 (each within the scatter of the next).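

Exchanging 3,5-dimethoxyphenyl for 2,3-dimethoxyphenyl on a carbon with a double bond to nitrogen gives a 1.1-fold higher number from compound 2 to compound 3 (0.03 log units; within the scatter) in this assay, so these two arrangements of the methoxy groups cannot be told apart here. Compound 3 also stands apart from the 4-methoxyphenyl compound, with a 2.7-fold higher number from compound 1 to compound 3 (0.43 log units; beyond the scatter), in the same direction as a 2.5-fold higher number from compound 1 to compound 2 (0.40 log units; beyond the scatter). No measurement bears on why these numbers fall as they do. The compounds shown leave open whether a phenyl carrying an amine or a carboxylic acid instead of methoxy groups would give a lower number than compound 1 at this position.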